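The compounds below may be only part of what the source reports. "The series", "measured", "known", "first", "only" and "open" are said of these compounds alone.

Measured in an assay on isolated protein for inhibition of 2-Hydroxyacid oxidase 2 (Homo sapiens), tested at 10 uM; on this read-out higher numbers stand for a stronger effect at the one concentration tested and lower numbers for a weaker effect:

- compound 1 `Cc1n[nH]c(C(=O)O)c1Cc1cccc(C(F)(F)F)c1` gives 23%
- compound 2 `Cc1n[nH]c(C(=O)O)c1Cc1cccc(-c2ccc(C(F)(F)F)cc2)c1` gives 30%
- compound 3 `Cc1n[nH]c(C(=O)O)c1Cc1cccc(-c2ccc(C(=O)O)cc2)c1` gives 15%

Compound 1 stands between the other two in this assay, yet its gap to compound 2 and its gap to compound 3 each lie within the usual scatter, so no order among those pairs can be read from these numbers. Compound 2 and compound 3 share a core; the difference between that core and the core of compound 1 is not broken down here.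

One change is measured directly: carboxy in place of trifluoromethyl on an aromatic carbon, which gives a number 15 percentage points lower from compound 2 to compound 3 (beyond the scatter).

Compound 4 `Cc1n[nH]c(C(=O)O)c1Cc1cccc(C(=O)O)c1` is not yet measured. It differs from compound 1 by carboxy in place of trifluoromethyl on an aromatic carbon. Going by the values given here, this is the same kind of change as the one from compound 2 to compound 3, not the same: around the place, the aromatic carbon is meta to a large group in compound 1 and compound 4, whereas it is para to a large group in compound 2 and compound 3.

Expectation for this assay: the step from compound 1 to compound 4 is estimated as a number 15 percentage points lower from compound 1 to compound 4 (beyond the scatter), set beside the measured a number 15 percentage points lower from compound 2 to compound 3 (beyond the scatter), since that is the only occurrence of this kind of change with numbers on both sides. On that basis compound 4 is expected to give about 8%, with an estimated range from -4% to 20%. The estimate rests on a single measured step made at a different place, so it carries little weight.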

Compound 4, a percentage reported as inhibition, at one concentration (the size of the read-out at that concentration, not a potency): 0%
For compound 4 the middle estimate is 8 percentage points above the measured one; low and high end bracket the measured number.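

In this assay, carboxy in place of trifluoromethyl on an aromatic carbon gives a number 23 percentage points lower from compound 1 to compound 4 (beyond the scatter), so the change also lowers the read-out on the core of compound 1. Set beside the earlier step, the direction is the same and the sizes cannot be told apart, so in this series the change carries from one core to the other as far as these two pairs go: the same change on two cores in this assay, a number 15 percentage points lower (beyond the scatter) from compound 2 to compound 3 and a number 23 percentage points lower (beyond the scatter) from compound 1 to compound 4, 8 percentage points apart, within the scatter of two such steps

This does not amount to a general rule for the series, since it rests on two pairs only, and the numbers are percentages at one concentration, which say nothing about how far potency moves between the cores.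

Still open, from the compounds shown here alone, is how a nitrile, a primary amide or a methyl ester on the same aromatic carbon would read relative to trifluoromethyl and carboxy, which would show whether the drop is specific to carboxy. Also open, going by these compounds, is whether a methyl ester or a primary amide in place of the carboxylic acid on the shared core would change the read-out on either core.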